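A few compounds are considered here, and "the series" means these few. Any claim that something is new, unique, unknown or untested is made for them only; others in the source may bear on it.

Working notes on the series. Compound 1 `Cc1cc(NC(=O)Cn2nnc(-c3ccccc3)n2)n(C2CCCCC2)n1` is one of two members with a number in an assay on HEK293 cells for activation of Kir3.1/Kir3.2 (Homo sapiens), read by thallium flux; on this read-out lower numbers stand for smaller maximal responses and higher numbers for larger maximal responses: compound 1 gives 92%, the lowest of the two numbers, and its nearest neighbour is compound 2 `Cc1cc(NC(=O)Cn2nnc(-c3ccccc3)n2)n(C2CCCC2)n1`, which in this assay gives 105%. Among the compounds with values here, the one step within the measured set, a number 13 percentage points higher from compound 1 to compound 2 (beyond the scatter), concerns a change on the aromatic nitrogen. Compound 3 `O=C(Cn1nnc(-c2ccccc2)n1)Nc1cc(C2(C(F)(F)F)CC2)nn1C1CCCCC1` carries a different substituent on the shared core, and in this assay compound 3 is reported as "not active" (no number reported), without a number.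

Compound 4 `Cc1cc(NC(=O)Cn2nnc(-c3ccc(C(F)(F)F)cc3)n2)n(C2CCCCC2)n1` differs from compound 1 by trifluoromethyl in place of hydrogen on an aromatic carbon. Within the data shown here, no measured step touches this position: the only quantified step, from compound 1 to compound 2, alters a different part of the molecule, and compound 3 changes yet another place. The phenyl change therefore has no precedent in the numbers shown, and the expectation rests on the maximal response of compound 1 alone. The step from compound 1 to compound 4 in this assay is expected to be a number 2 percentage points lower from compound 1 to compound 4 (within the scatter), that is, none beyond the scatter, with a wide range to reflect the lack of a guide. For compound 4 the estimate in this assay is 90%, between 60% and 110%.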

Compound 4, largest response reached (Emax), in percent of the reference or control that the assay uses: 94%
For compound 4 the middle estimate is 4 percentage points below the measured one; measured number inside the range.
By their numbers in this assay, from the lowest: compounds 1 and 4 (each within the scatter of the next); then compound 2.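

In this assay the change from phenyl to 4-(trifluoromethyl)phenyl gives a number 2 percentage points higher from compound 1 to compound 4 (within the scatter), so trifluoromethyl on this aromatic carbon, para to a large group, is compatible with the maximal response of compound 1. Within the data shown here, the earlier compounds varied only the aromatic nitrogen and another substituent on the shared core, so this is the first reading for a change on the phenyl ring, and here 4 heavy atoms enter without a step beyond the scatter. Nothing available bears on why the response holds at this position.

The compounds shown leave open whether an amine or a carboxylic acid on this aromatic carbon would read the same way. Also open, on these data alone, is whether the same trifluoromethyl change on compound 2, with cyclopentyl on the aromatic nitrogen, would stay within the scatter.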